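Arylidene semicarbazides of a naphthyl urea: step to compound 4

A few compounds are considered here, and "the series" means these few. Any claim that something is new, unique, unknown or untested is made for them only; others in the source may bear on it.

Compounds measured in a functional assay on the whole organism (strain Swiss albino) with Mus musculus as the target, with a stated time of 0.5 h (a higher number here means that more compound is needed for the effect, a lower number that less compound is needed), so far:
compound 1 `O=C(N/N=C/c1ccccc1[N+](=O)[O-])Nc1cccc2ccccc12`: 300 mg/kg
compound 2 `COc1ccc(/C=N/NC(=O)Nc2cccc3ccccc23)cc1OC`: 100 mg/kg
compound 3 `COc1cccc(/C=N/NC(=O)Nc2cccc3ccccc23)c1`: 100 mg/kg

Compound 3 and compound 2 give the same figure in this assay, and together they hold the lowest number of the three; compound 1 needs a higher dose than either, and that gap lies beyond the scatter. Among the measured compounds shown here, the one single-point step known is no change at the digits printed from compound 2 to compound 3 (within the scatter), so removing a methoxy from the aryl ring leaves the dose where it was.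

Compound 4 `O=C(N/N=C/c1ccccc1Cl)Nc1cccc2ccccc12` differs from compound 3 as follows: 2-chlorophenyl in place of 3-methoxyphenyl on a carbon with a double bond to nitrogen. For the measured compounds named here, no measured pair exchanges a methoxy-bearing ring for a chlorine-bearing one, so the step from compound 2 to compound 3 is the only direct guide, and it shows no movement. Compound 1, which also carries a substituent other than methoxy on the aryl ring, gives a higher number than compound 3, which argues for some caution. The step to compound 4 is therefore expected to be a 1.5-fold higher number from compound 3 to compound 4 (0.18 log units; within the scatter), a modest rise at most, and possibly none beyond the scatter. Compound 4 is estimated to give 150 mg/kg in this assay, within a range of 75 mg/kg to 300 mg/kg.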

Compound 4, minimum effective dose: 300 mg/kg
For compound 4 the middle estimate is 2.0-fold (0.30 log units) below the measured one; the measured number falls inside the stated range.
By their numbers in this assay, from the lowest: compounds 2 and 3 (each within the scatter of the next); then compounds 1 and 4 (each within the scatter of the next).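

In this assay, among the compounds shown here, 2-chlorophenyl in place of 3-methoxyphenyl on a carbon with a double bond to nitrogen gives a 3.0-fold higher number from compound 3 to compound 4 (0.48 log units; beyond the scatter) and is the first single-place step to lie beyond the scatter, so the dose at this position does depend on the aryl group it carries. Chloro in place of nitro on an aromatic carbon gives no change at the digits printed from compound 1 to compound 4 (within the scatter) in this assay and so does not separate these two substituents, which leaves the methoxy-bearing compound 2 and compound 3 at the lower numbers and compound 1 and compound 4 at the higher ones, with none of the four going against that split. Nothing at hand accounts for this split.

The step from 3-methoxyphenyl to 2-chlorophenyl changes both the substituent and its place on the ring, so the shift cannot be assigned to either alone, and a methoxy and a chloro at the same ring place would be needed to separate them. On these data alone, it also remains open how the plain phenyl group, or a ring bearing an amine or a carboxylic acid, would stand against these four compounds.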